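Series notes: from compound 2 to compound 4

A few compounds are considered here, and "the series" means these few. Any claim that something is new, unique, unknown or untested is made for them only; others in the source may bear on it.

Three compounds have numbers in a functional assay on CHO cells for antagonist activity at sphingosine 1-phosphate receptor 2 (Homo sapiens), read by calcium flux; on this read-out higher numbers stand for weaker inhibition and lower numbers for stronger inhibition. Compound 1 `CCOc1cc2[nH]c(Cc3nn(CC(=O)N4CCOCC4)c(=O)c4ccccc34)nc2cc1Cl` gives 10 nM and compound 3 `O=C(Cc1nn(C2CCNC2)c(=O)c2ccccc12)Nc1ccc(OC(F)(F)F)c(Cl)c1` gives 94 nM. Compound 2 `C[C@@H](C(=O)O)c1nn(Cc2cn3cc(OCC4CC4)c(Cl)cc3n2)c2ccccc2c1=O` gives 24 nM, the second highest of the three, beyond the scatter from both compound 1 and compound 3. Compound 4 `CC(C)(C(=O)O)c1nn(Cc2cn3cc(OCC4CC4)c(Cl)cc3n2)c2ccccc2c1=O` is not yet measured. It differs from compound 2 by 1-carboxy-1-methylethyl in place of 1-carboxyethyl on an aromatic carbon, and the defined stereocentre is gone. Among the compounds with values here, no step between measured compounds of this kind is available for comparison. The step of a 1.5-fold higher number from compound 2 to compound 4 (0.16 log units; within the scatter) is expected to be small, toward a somewhat higher number or none beyond the scatter. For compound 4 the estimate in this assay is 35 nM, with a range from 12 nM to 100 nM.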

Compound 4, half-maximal inhibitory concentration in the sphingosine 1-phosphate receptor 2 assay: 7.7 nM
For compound 4 the middle estimate is 4.5-fold (0.66 log units) above the measured one, outside the stated range (below it).
By their numbers in the sphingosine 1-phosphate receptor 2 assay, from the lowest: compounds 4 and 1 (each within the scatter of the next); then compound 2; then compound 3.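

In the sphingosine 1-phosphate receptor 2 assay the change of 1-carboxyethyl to 1-carboxy-1-methylethyl gives a 3.1-fold lower number from compound 2 to compound 4 (0.49 log units; beyond the scatter), so this aromatic carbon accepts the larger group, and activity at this level does not depend on the defined stereocentre. In a physicochemical assay for lipophilicity, at pH 7.4 (a higher number here means a more lipophilic compound, a lower number a more polar compound), compound 2 gives 2.41 and compound 4 gives 2.95. In the physicochemical assay the same change also makes the compound more lipophilic: the measured distribution coefficient of compound 2, 2.41, and of compound 4, 2.95, a number 0.54 log units higher (beyond the scatter)

The compounds shown do not separate the effect of the added methyl from that of losing the stereocentre. Going by these compounds, whether a tetrazole in place of the carboxylic acid, or a longer chain such as ethyl in place of the added methyl, would hold this activity also stays open.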